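Replacing cyano with fluoro at the top of the range

A few compounds are considered here, and "the series" means these few. Any claim that something is new, unique, unknown or untested is made for them only; others in the source may bear on it.

In a physicochemical assay for lipophilicity, read by HPLC, at pH 7.4 (a lower number here means a more polar compound, a higher number a more lipophilic compound), compound 3 (`Cc1ccccc1C(=O)Nc1ccc(C#N)cn1`) gives 3.9, the highest of the three measured numbers. Compound 1 (`Cc1ccccc1C(=O)Nc1cc(Cl)ccn1`) stands lower at 3.4, and compound 2 (`COc1ccc(NC(=O)c2ccccc2C)nc1`) is furthest away at 2.5. Compound 4 (`Cc1ccccc1C(=O)Nc1ccc(F)cn1`) carries fluoro in place of cyano on an aromatic carbon. Among the measured compounds shown here, one measured step bears on this position, the large one with cyano in place of methoxy on an aromatic carbon, which gave a number 1.40 log units higher from compound 2 to compound 3 (beyond the scatter). For the measured compounds named here, that step shows what entry of the cyano group did against methoxy, but no measured compound carries fluoro, so it gives only a loose guide. With compound 3 at 3.9 at the top of the set, losing its cyano is expected to bring the number down, though by less than the large step, and towards the level of compound 1 at 3.4. The step expected in this assay is a number 0.50 log units lower from compound 3 to compound 4 (beyond the scatter). Compound 4 is estimated at 3.4, with an expected range from 3 to 3.8.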

Compound 4, distribution coefficient: 2.7
Compound 4: the middle estimate sits 0.70 log units above what was measured, and the stated range ends above it.
By their numbers in this assay, from the lowest: compounds 2 and 4 (each within the scatter of the next); then compound 1; then compound 3.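

In this assay, fluoro in place of cyano on this aromatic carbon gives a number 1.20 log units lower from compound 3 to compound 4 (beyond the scatter) as a large step, so the high number of compound 3 does not carry over to the smaller group. Fluoro in place of methoxy gives a number 0.20 log units higher from compound 2 to compound 4 (within the scatter) and so leaves the two compounds indistinguishable, which means that among the three groups compared at this position, only cyano stands apart. Nothing available explains why cyano differs from the other two groups here.

Going by these compounds, whether cyano is alone in this remains open, since a trifluoromethyl group, an amine or a carboxylic acid at the same position could fall on either side. The compounds shown also leave open whether these steps would hold with chloro present on the same ring.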